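The source may report more compounds than this note shows. Statements on the series, on what has been measured and on what is new or still open speak of the compounds shown alone.

In an ADME assay on Vero cells (Chlorocebus sabaeus) for cytotoxicity, read by MTT assay, with a stated time of 72 h (on this read-out higher numbers stand for lower toxicity in this test and lower numbers for higher toxicity in this test), compound 1 `CC/C(=C\c1ccc(Cl)cc1)C(=O)/C=C/c1ccc([N+](=O)[O-])cc1` gives 36000 nM. This places it within the scatter of compound 2 `COc1ccc(/C=C(\C)C(=O)/C=C/c2ccc(Br)cc2)cc1`, which gives 31200 nM. Compound 3 `COc1ccc(/C=C(\C)C(=O)/C=C/c2ccc(/C=C/C(=O)/C(C)=C/c3ccc(OC)cc3)cc2)cc1` gives 460000 nM, a higher number than that of compound 1 and one well beyond the scatter.

Compound 4 `CC/C(=C\c1ccc(Cl)cc1)C(=O)/C=C/c1ccc(C=O)cc1`, not yet measured, keeps the core of compound 1 and differs from it in one place: formyl in place of nitro on an aromatic carbon.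

Among the compounds with values here, no two measured compounds differ in only one place, so the data offer no direct precedent for this exchange. The expectation therefore rests on compound 1 itself, and no change beyond the scatter is expected in this assay, in either direction. The estimated step is a 1.2-fold lower number from compound 1 to compound 4 (0.08 log units; within the scatter), which would remain within the scatter. For compound 4 the expected value is 30000 nM, with an estimated range from 12000 nM to 75000 nM.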

Compound 4, half-maximal cytotoxic concentration: 46900 nM
Compound 4: middle estimate off by 1.6-fold (0.19 log units), on the low side, and the stated range covers the measured number.
By their numbers in this assay, from the lowest: compounds 2, 1 and 4 (each within the scatter of the next); then compound 3.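

Formyl in place of nitro gives the first step that can be read in this series, and in this assay it is a 1.3-fold higher number from compound 1 to compound 4 (0.11 log units; within the scatter), so this exchange on an aromatic carbon para to a large group stays within the scatter. The earlier compounds shown here could not show this, as no two of them differed in only one place. Nothing measured here bears on why the two groups read alike in this test.

The compounds shown leave open whether an amine, a carboxylic acid or a methoxy group at this same place would also stay within the scatter of compound 1. From the compounds shown here alone, it also remains open whether formyl in place of nitro would give a similar step on a different core.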